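The source may report more compounds than this note shows. Statements on the series, on what has been measured and on what is new or still open speak of the compounds shown alone.

Series notes. The measured set so far comprises compound 1 `C[C@H](NC(=O)CN(c1nc(Cl)nc2[nH]cnc12)C1CC1)C(=O)OCc1ccccc1`, compound 2 `CC[C@H](C)[C@H](NC(=O)CN(c1ncnc2c1ncn2C1CCCCO1)C1CC1)C(=O)OCc1ccccc1` and compound 3 `O=C(OCc1ccccc1)[C@@H]1CCCN1C(=O)CN(c1ncnc2c1ncn2C1CCCCO1)C1CC1`. In a functional assay on the whole organism (Tail, strain ICR) with Mus musculus as the target, in the tail flick test, with a stated time of 150 min, at a dose of 25 umol/kg by the oral route (on this read-out higher numbers stand for a stronger effect at the one dose given and lower numbers for a weaker effect), compound 1 gives 23%, compound 2 gives 16.4% and compound 3 gives 7.85%. Compound 1 carries the highest of the three numbers; its gap to compound 2 lies within the scatter, so no order between those two can be read, while its gap to compound 3 lies beyond the scatter. Going by the values given here, compound 2 and compound 3 share a core that differs from the core of compound 1, so no step between measured compounds that differ in one place exists in this set.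

Compound 4 `CC[C@H](C)[C@H](NC(=O)CN(c1nc(Cl)nc2[nH]cnc12)C1CC1)C(=O)OCc1ccccc1` is not yet measured. It differs from compound 1 in one place: sec-butyl in place of methyl on a saturated chain carbon bound to an amide-type nitrogen and a carbonyl carbon. Compound 2 already carries the sec-butyl group, on the other core, and with 16.4% compound 2 sits within the scatter of compound 1, which gives no sign that this group by itself moves the read-out far. Among the compounds with values here, no measured pair isolates the change, so its size remains open. The step from compound 1 to compound 4 in this assay is expected to be small, a number 4 percentage points lower from compound 1 to compound 4 (within the scatter), and not beyond the scatter in either direction. Compound 4 is therefore estimated at 19% in this assay, with a range from 9% to 30%.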

Compound 4, a percentage reported as activity, at one dose (the size of the read-out at that dose, not a potency): 6.9%
Compound 4: middle estimate off by 12.1 percentage points, on the high side, and the stated range ends above it.
By their numbers in this assay, from the lowest: compounds 4, 3, 2 and 1 (each within the scatter of the next, the first and the last beyond it).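

On the shared core, in this assay, sec-butyl in place of methyl on a saturated chain carbon bound to an amide-type nitrogen and a carbonyl carbon gives a number 16.1 percentage points lower from compound 1 to compound 4 (beyond the scatter) at the one dose given. Going by these compounds alone, this is the first step that isolates a single change, and it shows that this position is not neutral: exchanging this one group moves the read-out beyond the scatter, which the earlier compounds, differing in more than one place, could not show. Nothing given here bears on the origin of this step.

Only methyl and sec-butyl stand at this position on the shared core, so an ethyl or isopropyl group would be needed to tell whether the read-out falls gradually along this series of chains or only with the larger group, and a side chain carrying an amine or a carboxylic acid would test a different kind of group at the same carbon. Whether the exchange of methyl for sec-butyl has a similar effect on the core of compound 2 also remains open, as that core has no methyl partner among the compounds shown.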